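The source may hold more compounds than are shown below. What is called first, only, known or untested is meant among the compounds shown, and "the series" means these compounds.

Measured in a functional assay on HeLa cells (Homo sapiens) for cytotoxicity, read by resazurin assay, with a stated time of 72 h; a higher number here means a weaker inhibitor, a lower number a stronger inhibitor:
- Compound 1 `CCSC(=S)SCC(=O)c1cccc(NS(=O)(=O)c2ccc(Cl)cc2)c1`: 46600 nM
- Compound 2 `COCCSC(=S)SCC(=O)c1ccc(OC)cc1`: 7880 nM
- Compound 3 `CCSC(=S)SCC(=O)c1ccc(S(=O)(=O)Nc2ccc(OC)cc2)cc1`: 4320 nM

Within the data shown here, only three numbers are available, so the picture is thin. Compound 2, at 7880 nM, lies within the usual scatter of compound 3, at 4320 nM, so these two cannot be told apart. Compound 1, at 46600 nM, has a number clearly higher than compound 2, beyond the scatter, which makes it the weaker inhibitor of that pair.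

The next compound to be tested is compound 4 `CCOC(=S)SCC(=O)c1ccc(OC)cc1`. Compared with compound 2, it carries one change: ethoxy in place of (2-methoxyethyl)sulfanyl on a thiocarbonyl carbon. The rest of the structure stays the same.

Among the measured compounds shown here, no pair of measured compounds differs in only one place, so the data do not show directly what this swap does in this assay. The best starting point is therefore compound 2 itself, at 7880 nM, the closest measured relative. With no evidence for a direction, no shift beyond the scatter is expected. The estimated step is a 1.1-fold higher number from compound 2 to compound 4 (0.06 log units; within the scatter). For compound 4 the expected value is 9000 nM, with an estimated range of 3000 nM to 27000 nM.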

Compound 4, half-maximal inhibitory concentration: 4640 nM
The estimate for compound 4 lay 1.9-fold (0.29 log units) above the measured number; the range from low to high includes it.
By their numbers in this assay, from the lowest: compounds 3, 4 and 2 (each within the scatter of the next); then compound 1.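

Among these compounds, this is the first pair of compounds that differ in only one place, so it gives the first direct look at the group on the thiocarbonyl carbon: in this assay, ethoxy in place of (2-methoxyethyl)sulfanyl gives a 1.7-fold lower number from compound 2 to compound 4 (0.23 log units; within the scatter). The change takes this group from 5 heavy atoms to 3, removes its sulfur and leaves one hydrogen-bond acceptor fewer, yet the two compounds cannot be told apart, so for this pair the exchange leaves the cytotoxicity read-out unchanged within the usual scatter. No independent measurement is available to explain why these two compounds read alike.

The compounds shown leave open whether this position would accept a different kind of group on the thiocarbonyl carbon, such as an amine or a longer chain like butoxy, where a step beyond the scatter could still appear. They also leave open whether ethoxy would behave the same way on the larger structure of compound 3, since this single pair speaks only for the core it shares.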